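This account rests on a few compounds, and the source may have more. Where it says the series, first, only, none or still open, it means among the compounds named here.

Compound 1 `O=C(O)Cn1nc(Cc2nc3cc(Cl)c(OCC(F)F)cc3[nH]2)c2ccccc2c1=O`: 12 nM
Compound 2 `CCC(C(=O)O)c1nn(Cc2cn3cc(OCC4CC4)c(Cl)cc3n2)c2ccccc2c1=O`: 5.6 nM

Of the compounds shown here, two have so far been measured in a functional assay on CHO cells for antagonist activity at sphingosine 1-phosphate receptor 2 (Homo sapiens), read by calcium flux; on this read-out higher numbers stand for weaker inhibition and lower numbers for stronger inhibition. Compound 2 gives the lowest number of the two; its nearest neighbour is compound 1, whose number is higher by a gap that lies beyond the usual scatter. Compound 3 `O=C(O)Cc1nn(Cc2cn3cc(OCC4CC4)c(Cl)cc3n2)c2ccccc2c1=O` keeps the core of compound 2 and differs from it in one place: hydrogen in place of ethyl on a saturated chain carbon bound to an aromatic carbon and a carbonyl carbon. Within the data shown here, no step between measured compounds isolates this change, so the expectation rests on compound 2 alone. For compound 3 the expected step is a 2.1-fold higher number from compound 2 to compound 3 (0.33 log units; beyond the scatter), a modest rise in the number. Compound 3 is expected to give 12 nM, within a range from 4 nM to 40 nM.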

Compound 3, half-maximal inhibitory concentration in the sphingosine 1-phosphate receptor 2 assay: 20 nM
The estimate for compound 3 lay 1.7-fold (0.22 log units) below the measured number, and the stated range covers the measured number.
By their numbers in the sphingosine 1-phosphate receptor 2 assay, from the lowest: compound 2; then compounds 1 and 3 (each within the scatter of the next).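

Among these compounds, in the sphingosine 1-phosphate receptor 2 assay, hydrogen in place of ethyl on the saturated chain carbon bound to an aromatic carbon and a carbonyl carbon gives a 3.6-fold higher number from compound 2 to compound 3 (0.55 log units; beyond the scatter), the first reading of this position, and it shows that inhibition is stronger with the ethyl present. In a physicochemical assay for solubility, measured as thermodynamic solubility, at pH 7.4 (on this read-out lower numbers stand for lower solubility and higher numbers for higher solubility), compound 2 gives 359 ug/mL and compound 3 gives 919 ug/mL, so of this pair the compound with weaker inhibition, compound 3, is the more soluble. The compounds shown leave open whether methyl or a longer chain on this carbon would combine the inhibition of compound 2 with the solubility of compound 3.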